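Swapping a Saturated Ring for a Chlorothiazole

This account rests on a few compounds, and the source may have more. Where it says the series, first, only, none or still open, it means among the compounds named here.

Measured so far:
Compound 1 `CN1CCN(CC2CCOC2)/C(=N\C#N)C1=O` gives 517 nM.
Compound 2 `CN(C)C(=O)/C(=N\C#N)N(C)Cc1ccc(Cl)nc1` gives 3830 nM.
Compound 3 `NC(=S)N/N=C1/NCCN(Cc2ccc(Cl)nc2)C1=O` gives 3920 nM.

All three values come from an assay on membranes from Head for displacement of a labelled ligand from Nicotinic acetylcholine receptor alpha 5 subunit (Musca domestica), read by scintillation counting, with a stated time of 1 h; on this read-out higher numbers stand for weaker inhibition and lower numbers for stronger inhibition. Compound 1 stands lowest of the three; compound 2 and compound 3 both lie well beyond the usual scatter above it, so compound 1 is the stronger inhibitor of the set. The next compound, compound 4 `CN1CCN(Cc2cnc(Cl)s2)/C(=N\C#N)C1=O`, keeps the core of compound 1 and changes one group: 2-chloro-1,3-thiazol-5-yl in place of oxolan-3-yl on a saturated chain carbon bound to an amine nitrogen in a ring. Among the measured compounds shown here, no step between two measured compounds carries this exact change, so the expectation rests on compound 1 and the swap itself. A moderate step toward stronger inhibition in this assay is expected, a 3.4-fold lower number from compound 1 to compound 4 (0.54 log units; beyond the scatter). Compound 4 is therefore estimated at 150 nM, within a range from 30 nM to 700 nM.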

Compound 4, inhibition constant: 4 nM
Beside the measured number, compound 4's estimate is 38-fold (1.57 log units) above it; the measured number lies below the stated range.
By their numbers in this assay, from the lowest: compound 4; then compound 1; then compounds 2 and 3 (each within the scatter of the next).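

In this assay, the place on a saturated chain carbon bound to an amine nitrogen in a ring proves highly sensitive: 2-chloro-1,3-thiazol-5-yl in place of oxolan-3-yl gives a 130-fold lower number from compound 1 to compound 4 (2.11 log units; beyond the scatter) on an otherwise unchanged core. The earlier compounds shown here differed in more than one place, so they could not show that this single swap moves the number so far. Nothing available explains why this group does so much better. On these data alone, how a phenyl ring, or the same thiazole with a methyl group instead of chlorine, would read at this place remains open.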